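Two Measured Ethers and One Awaiting a Number

This account rests on a few compounds, and the source may have more. Where it says the series, first, only, none or still open, it means among the compounds named here.

Compound 1 `Cc1c(C)c2ccc(OC(C)c3ccc(C(C)C)cc3)cc2oc1=O` gives > 10000 nM in an assay on brain for inhibition of Amine oxidase [flavin-containing] A (Rattus norvegicus) (on this read-out lower numbers stand for stronger inhibition and higher numbers for weaker inhibition), which is a limit of the assay rather than a number.
Compound 2 `Cc1c(C)c2ccc(OCc3ccccn3)cc2oc1=O` gives 1800 nM in this assay.

Both share the same core and differ in the group carried on the ether oxygen. Going by the values given here, compound 2 stands as the only compound with a true number in this assay; the other value shown is a limit (the limit of > 10000 nM in this assay, at which 1 of the 2 values shown sits). Compound 3 `Cc1nnc(COc2ccc3c(C)c(C)c(=O)oc3c2)o1` has not yet been measured. It differs from compound 2 by a single exchange: 5-methyl-1,3,4-oxadiazol-2-yl in place of pyridin-2-yl on a saturated chain carbon bound to an oxygen on an aromatic ring. Both groups carry six heavy atoms, but the entering ring is smaller and holds more hetero atoms and more hydrogen-bond acceptors. Among the compounds with values here, nothing measured between two compounds here tells how such an exchange plays out, so the expectation rests on the single number of compound 2 alone. The expected step from compound 2 to compound 3 is a 1.7-fold higher number from compound 2 to compound 3 (0.22 log units; within the scatter), a modest shift toward weaker inhibition that may still fall within the usual scatter. Compound 3 is therefore estimated at 3000 nM, with a likely range from 700 nM to 13000 nM.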

Compound 3, half-maximal inhibitory concentration: 5600 nM
Compound 3: the middle estimate sits 1.9-fold (0.27 log units) below what was measured; low and high end bracket the measured number.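

In this assay, going by these compounds alone, this is the first step that can be read at this place, on a saturated chain carbon bound to an oxygen on an aromatic ring: 5-methyl-1,3,4-oxadiazol-2-yl in place of pyridin-2-yl gives a 3.1-fold higher number from compound 2 to compound 3 (0.49 log units; beyond the scatter). Both groups carry the same number of heavy atoms, so the result shows that the heavy-atom count alone does not settle the inhibition seen at this place; the kind of ring matters too. The entering ring differs in more than one way, being five-membered and holding more hetero atoms and more hydrogen-bond acceptors, and a single step cannot show which of these differences counts.

On these data alone, a phenyl ring, a pyridin-3-yl ring or a carboxylic acid at the same place would help separate ring size from the number and kind of hetero atoms, so the source of this step remains open. How far any of these results extends to the larger group of compound 1 also remains open, as its value is a limit and no step to it can be read: the limit of > 10000 nM in this assay, at which 1 of the 3 values shown sits.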